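Hydroxamic acid series: amide-linked analogue with shifted indole fluorine

This account rests on a few compounds, and the source may have more. Where it says the series, first, only, none or still open, it means among the compounds named here.

Measured so far:
Compound 1, `O=C(COc1ccc(CN2CC=C(c3c[nH]c4ccc(F)cc34)CC2)cc1)NO`: 949 nM
Compound 2, `O=C(COc1ccc(C(=O)N2CC=C(c3c[nH]c4ccc(F)cc34)CC2)cc1)NO`: > 5000 nM

In a functional assay on HCT-116 cells (Homo sapiens) for antiproliferative activity, with a stated time of 72 h (on this read-out higher numbers stand for weaker inhibition and lower numbers for stronger inhibition), compound 1 gives 949 nM. For compound 2 this assay reports only a limit, > 5000 nM, and no number. Among the measured compounds shown here, compound 2 thus stands at the limit of > 5000 nM in this assay, at which 1 of the 2 values shown sits, the weak end of the two values shown; no single-point step joins compound 1 and compound 2, so the two readings are placed side by side without further comparison.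

Compound 3, `O=C(COc1ccc(C(=O)N2CC=C(c3c[nH]c4cccc(F)c34)CC2)cc1)NO`, is not yet measured. It differs from compound 2 by 4-fluoro-1H-indol-3-yl in place of 5-fluoro-1H-indol-3-yl on a double-bonded ring carbon. The amide linker and the rest of the shared core are kept. For the measured compounds named here, no step between measured compounds exists in this set, and compound 2 offers only a limit, so the change has no measured step to be scaled against. The step from compound 2 to compound 3 is expected to be none beyond the scatter, a step that the limit leaves unreadable from compound 2 to compound 3, with a real chance that this assay again returns only a limit. Compound 3 is estimated at 6000 nM in this assay, in a range from 2000 nM to 20000 nM.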

Compound 3, half-maximal inhibitory concentration: 1410 nM
Beside the measured number, compound 3's estimate is 4.3-fold (0.63 log units) above it, outside the stated range (below it).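

In this assay, among the compounds shown here, 4-fluoro-1H-indol-3-yl in place of 5-fluoro-1H-indol-3-yl on the double-bonded ring carbon gives the first readable step in this set: an at least 3.5-fold lower number from compound 2 to compound 3 (0.54 log units; beyond the scatter). Compound 2 and compound 3 hold the same atoms joined differently, with the amide linker and the rest of the shared core kept, so where the fluorine sits on this group is enough to move the read-out beyond the scatter. The size of the step remains a lower bound only, because compound 2 carries a limit and not a number: the limit of > 5000 nM in this assay, at which 1 of the 3 values shown sits.

The compounds shown leave open how large the step really is and whether the same fluorine shift would count equally with the linker of compound 1, which carries no carbonyl. They also leave open what the unsubstituted 1H-indol-3-yl group, or a chlorine or a methoxy group in place of the fluorine, would give on the double-bonded ring carbon of this series in this assay.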